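The source may report more compounds than this note shows. Statements on the series, on what has been measured and on what is new or still open speak of the compounds shown alone.

Measured in an ADME assay on Huh-7 cells (Homo sapiens) for cytotoxicity (on this read-out lower numbers stand for higher toxicity in this test and higher numbers for lower toxicity in this test), so far:

- compound 1, `Cc1ccccc1-c1nn(-c2ccc(Cl)cc2)cc1CNCCN1CCN(C)CC1`: 17000 nM
- compound 2, `Cc1ccccc1-c1nn(-c2ccc(C(F)(F)F)cc2)cc1CNCCN1CCN(C)CC1`: 11000 nM
- compound 3, `CCCN1CCC(CNCc2cn(-c3ccc(C(F)(F)F)cc3)nc2-c2ccc(C(F)(F)F)cc2)CC1`: 1200 nM

Compound 2 to compound 1 carries the change (chloro in place of trifluoromethyl on an aromatic carbon), and the step was a 1.5-fold higher number from compound 2 to compound 1 (0.19 log units; within the scatter). Compound 3 sits apart from the other two; how its core differs from the core of compound 2 is not broken down here, and its value is the lowest of the three by a step beyond the scatter in each case.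

Compound 4, `CCCN1CCC(CNCc2cn(-c3ccc(C(F)(F)F)cc3)nc2-c2ccc(Cl)cc2)CC1`, has not yet been measured in this assay. It differs from compound 3 by chloro in place of trifluoromethyl on an aromatic carbon, the same change that separates compound 2 from compound 1, at the same place. The step from compound 3 to compound 4 is expected to be a 1.3-fold higher number from compound 3 to compound 4 (0.12 log units; within the scatter), because the matching step a 1.5-fold higher number from compound 2 to compound 1 (0.19 log units; within the scatter) lay within the scatter. Compound 4 is therefore estimated at 1600 nM, with a range from 700 nM to 3500 nM.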

Compound 4, half-maximal cytotoxic concentration: 1900 nM
Estimate against measurement, compound 4: 1.2-fold (0.07 log units) below; the measured number falls inside the stated range.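

In this assay, chloro in place of trifluoromethyl on an aromatic carbon gives a 1.6-fold higher number from compound 3 to compound 4 (0.20 log units; within the scatter), and the step matches the one on the other core: the same change on two cores in this assay, a 1.5-fold higher number (0.19 log units; within the scatter) from compound 2 to compound 1 and a 1.6-fold higher number (0.20 log units; within the scatter) from compound 3 to compound 4, 1.0-fold (0.01 log units) apart, within the scatter of two such steps. In this pair of cores, the change therefore carries over without a detectable difference, and on neither core does it separate the two compounds beyond the scatter. This does not establish a real shift of shared size, and two cores say nothing about how the change behaves on any other core.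

On these data alone, whether fluoro, methoxy or a nitrile at the same place would also stay within the scatter remains open. So does the outcome of a longer chain in place of the propyl group of compound 4.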